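Propyl in place of bromo on compound 2

The source may report more compounds than this note shows. Statements on the series, on what has been measured and on what is new or still open speak of the compounds shown alone.

In a functional assay on BV-2 cells (Mus musculus) for inhibition, read by Griess assay, with a stated time of 24 h (on this read-out higher numbers stand for weaker inhibition and lower numbers for stronger inhibition), compound 1 `C=CCn1ccc(-c2cc(Br)ccc2O)n1` gives 112000 nM. Compound 2 `Oc1ccc(Br)cc1-c1ccn(-c2ccccc2)n1` reads > 200000 nM, which is a limit. Compound 3 `COc1ccc(Br)cc1-c1ccn(-c2ccccc2)n1` reads > 200000 nM, also a limit. Compound 2 thus stands at the limit of > 200000 nM in this assay, at which 2 of the 3 values shown sit.

Compound 4 `CCCc1ccc(O)c(-c2ccn(-c3ccccc3)n2)c1` carries propyl in place of bromo on an aromatic carbon, para to a hydroxy group: propyl in place of bromo on an aromatic carbon. Phenyl in place of allyl on an aromatic nitrogen gives an at least 1.7-fold higher number from compound 1 to compound 2 (0.25 log units; that floor lies within the scatter). Methyl in place of hydrogen on an oxygen gives a step that the two limits leave unreadable from compound 2 to compound 3. Neither change falls on that carbon, so no step beyond the scatter is expected in this assay. The expected step is a number no higher from compound 2 to compound 4 (the limit leaves the size open). Compound 4 is estimated at 200000 nM, with an expected range of 70000 nM to 400000 nM.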

Compound 4, half-maximal inhibitory concentration: 109000 nM
Compound 4: middle estimate off by 1.8-fold (0.26 log units), on the high side; measured number inside the range.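

In this assay, propyl in place of bromo on the aromatic carbon para to a hydroxy group gives an at least 1.8-fold lower number from compound 2 to compound 4 (0.26 log units; that floor lies within the scatter). Among the compounds shown here, this is the first change at this carbon, and it yields a measured number, with compound 4 at 109000 nM. Compound 2 remains a limit, so the true size of the step stays open: the limit of > 200000 nM in this assay, at which 2 of the 4 values shown sit.

Open, going by these compounds, is whether a longer chain, an amine or a carboxylic acid on this carbon would shift the number further. Also open, on these data alone, is whether propyl has the same effect with methyl on the oxygen, as in compound 3.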